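A few compounds are considered here, and "the series" means these few. Any claim that something is new, unique, unknown or untested is made for them only; others in the source may bear on it.

Working notes on the series, read in a functional assay on A549 cells (Homo sapiens) for antiproliferative activity, read by CCK-8 assay, with a stated time of 72 h; on this read-out lower numbers stand for stronger inhibition and higher numbers for weaker inhibition. Compound 1 `Nc1ccccc1NC(=O)c1ccc(COc2ccc([N+](=O)[O-])cc2)cc1` gives > 32000 nM, which is a limit and not a number. Among the compounds with values here, compound 2 `Nc1ccccc1NC(=O)c1ccc(COc2ccccc2)cc1` gives 6760 nM, the only true number so far, so its standing cannot yet be judged against a measured neighbour.

Compound 3 `CCc1ccc(OCc2ccc(C(=O)Nc3ccccc3N)cc2)cc1` differs from compound 2 by ethyl in place of hydrogen on an aromatic carbon, para to a large group. Within the data shown here, one measured step bears on this, namely an at least 4.7-fold lower number from compound 1 to compound 2 (0.67 log units; beyond the scatter), with hydrogen in place of nitro on an aromatic carbon. That step rests on (the limit of > 32000 nM in this assay, at which 1 of the 2 values shown sits), so its true size is open. Nitro is not ethyl, and the step gives no direct size for the new group. It shows only that, in this pair, a substituent on that carbon costs activity relative to hydrogen.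

On the strength of that single pair, a small move towards weaker inhibition is expected, close to the scatter and well short of the measured step. The estimated step is a 1.3-fold higher number from compound 2 to compound 3 (0.12 log units; within the scatter). For compound 3 the expected value is 9000 nM, with an estimated range from 3500 nM to 25000 nM.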

Compound 3, half-maximal inhibitory concentration: 6420 nM
The estimate for compound 3 lay 1.4-fold (0.15 log units) above the measured number; low and high end bracket the measured number.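

In this assay, ethyl in place of hydrogen on an aromatic carbon, para to a large group, gives a 1.1-fold lower number from compound 2 to compound 3 (0.02 log units; within the scatter), so a substituent at this place does not of itself cost activity, which the nitro pair alone could not show. Ethyl in place of nitro gives an at least 4.9-fold lower number from compound 1 to compound 3 (0.69 log units; beyond the scatter), so among these three compounds the weak result of compound 1 goes with nitro in particular and not with any group on this carbon. Compound 1 stands at a limit and not at a number, so the true size of that step remains open: the limit of > 32000 nM in this assay, at which 1 of the 3 values shown sits.

With only ethyl and nitro shown on this carbon, two groups give no trend, and it remains open whether a longer chain, a methoxy group, an amine or a carboxylic acid would read like ethyl or like nitro. Going by these compounds, it also remains open whether the step from phenyl to 4-ethylphenyl would stay within the scatter if the same ethyl group sat on another carbon of that ring.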